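Swapping Chloro for Amino: From Compound 2 to Compound 4

The source may report more compounds than this note shows. Statements on the series, on what has been measured and on what is new or still open speak of the compounds shown alone.

Of the compounds shown here, three bearing a chloromethyl-substituted benzyl group have been tested in a functional assay on NCI-H226 cells (Homo sapiens) for cytotoxicity, read by sulforhodamine B assay, with a stated time of 48 h; a higher number here means that more compound is tolerated, a lower number that less compound is tolerated. Compound 1 `ClCc1ccc(Cn2cnc3c(Cl)ncnc32)cc1` gives 49000 nM, compound 2 `ClCc1cccc(Cn2cnc3c(Cl)nc(Cl)nc32)c1` gives 40700 nM, and compound 3 `Nc1nc(Cl)c2ncn(Cc3ccccc3CCl)c2n1` gives 53700 nM. Compound 2 stands alongside the other two: its distance to compound 1 and to compound 3 lies within the usual scatter, so the three cannot be told apart. Compound 4 `Nc1nc(Cl)c2ncn(Cc3cccc(CCl)c3)c2n1` has not yet been measured. It differs from compound 2 by amino in place of chloro on an aromatic carbon. Going by the values given here, no step between measured compounds isolates this change. Compound 3 also carries the amino group and gives 53700 nM, close to compound 2, so no step beyond the scatter is expected in this assay. Compound 4 is therefore estimated at 48000 nM, within a range from 24000 nM to 96000 nM, an expected step of a 1.2-fold higher number from compound 2 to compound 4 (0.07 log units; within the scatter).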

Compound 4, concentration lethal to 50% of the cells: > 100000 nM
Compound 4: no number, only a limit; the forecaster's own chance of this, stated with the estimate: 15%; middle value at least 2.0-fold (0.31 log units) away from the limit.
By their numbers in this assay, from the lowest: compounds 2, 1 and 3 (each within the scatter of the next). At a limit, above all of these: compound 4.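

Amino in place of chloro on an aromatic carbon, between two ring nitrogen atoms, gives an at least 2.4-fold higher number from compound 2 to compound 4 (0.39 log units; beyond the scatter) in this assay, the first step beyond the scatter among these compounds. Differing from compound 4 in the place of the chloromethyl group and also carrying the amino group, compound 3 gives 53700 nM, so the amino group alone does not set this result. The value of compound 4 is a limit, not a number: the limit of > 100000 nM in this assay, at which 1 of the 4 values shown sits.

Going by these compounds, whether a methoxy or dimethylamino group in the same place would also give a step beyond the scatter stays open. So does the outcome with a hydroxymethyl group in place of chloromethyl.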